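Methoxy to Chloro: A Step Expected Within the Scatter

The compounds below may be only part of what the source reports. "The series", "measured", "known", "first", "only" and "open" are said of these compounds alone.

Among the compounds with values here, compound 2 `COc1ccc(-c2csc(N/N=C/c3ccc(Cl)cc3Cl)n2)cc1` gives 93.3% in a functional assay, read by spectrophotometry, with a stated time of 15 min, tested at 100 ug/mL; on this read-out higher numbers stand for a stronger effect at the one concentration tested and lower numbers for a weaker effect; the only other number, from compound 1 `Cc1ccc(-c2csc(N/N=C/c3ccc(Cl)cc3Cl)n2)cc1`, is 95.1%, and the step of a number 1.8 percentage points lower from compound 1 to compound 2 (within the scatter) lies within the scatter. Compound 3 `Clc1ccc(-c2csc(N/N=C/c3ccc(Cl)cc3Cl)n2)cc1` differs from compound 2 by chloro in place of methoxy on an aromatic carbon. Within the data shown here, the one measured step, a number 1.8 percentage points lower from compound 1 to compound 2 (within the scatter), also concerns this methoxy group and did not move the read-out beyond the scatter, so for compound 3 a step of a number 0.3 percentage points lower from compound 2 to compound 3 (within the scatter) is expected, none beyond the scatter. Compound 3 is therefore estimated at 93%, between 82% and 99%.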

Compound 3, a percentage reported as inhibition, at one concentration (the size of the read-out at that concentration, not a potency): 92.4%
Estimate against measurement, compound 3: 0.6 percentage points above, and the stated range covers the measured number.
By their numbers in this assay, from the lowest: compounds 3, 2 and 1 (each within the scatter of the next).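

In this assay the change from 4-methoxyphenyl to 4-chlorophenyl gives a number 0.9 percentage points lower from compound 2 to compound 3 (within the scatter) and chloro in place of methyl gives a number 2.7 percentage points lower from compound 1 to compound 3 (within the scatter) so methyl, methoxy and chloro all read alike at this position. The change also removes the one hydrogen-bond acceptor counted on methoxy, and the read-out stays within the scatter. Nothing available explains why these three groups read alike.

As far as these compounds go, whether an amine, a carboxylic acid or a longer chain at this position would read the same remains open. From the compounds shown here alone, the numbers give only the size of the effect at the single concentration tested, so how compound 1, compound 2 and compound 3 would read at any other concentration also remains open.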